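The compounds below may be only part of what the source reports. "The series", "measured", "known", "first", "only" and "open" are said of these compounds alone.

In an ADME assay on a cell-free system (plasma, Mus musculus) for protein binding (on this read-out higher numbers stand for a larger free fraction and lower numbers for a smaller free fraction), compound 1 `CC(C)COc1ncc(-c2cn(C)c3cc(C(=O)NS(=O)(=O)C4CC4)c(F)cc23)cc1Cl` reads 0.002 and compound 3 `CC(C)COc1ncc(-c2cn(C)c3cc(C(=O)NS(C)(=O)=O)c(F)cc23)cc1Cl` reads 0.002 at the digits given, while compound 2 `Cn1cc(-c2ccc(C(F)(F)F)cc2)c2ccc(C(=O)NS(=O)(=O)C3CC3)cc21` reads 0.004 within the scatter of both. Compound 1 therefore sits among three numbers that cannot be told apart, all of them very small free fractions.

Still unmeasured is compound 4 `CC(C)COc1ccc(-c2cn(C)c3cc(C(=O)NS(=O)(=O)C4CC4)c(F)cc23)cn1`, which keeps the core of compound 1 and differs in one place: hydrogen in place of chloro on an aromatic carbon on an aromatic carbon ortho to an isobutoxy group, hydrogen in place of chloro. Going by the values given here, the one measured single-place step, no change at the digits printed from compound 1 to compound 3 (within the scatter) (within the scatter), concerns the group on the sulfonyl sulfur and not this chloro, so it bears on the new change only indirectly. It shows that this read-out did not move there. Set against compound 1, compound 2 has no such chloro and differs in other places too, and at 0.004 it stays within the scatter, which is a weak hint at best.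

Among the compounds with values here, no measured step removes this chloro, so a small rise toward a larger free fraction is expected, probably not beyond the scatter. The expected step is a 2.0-fold higher number from compound 1 to compound 4 (0.30 log units; within the scatter) and it remains an estimate. For compound 4 the estimated value is 0.004 with an expected range from 0.002 to 0.008 in this measurement.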

Compound 4, unbound fraction: 0.006
Compound 4: the middle estimate sits 1.5-fold (0.18 log units) below what was measured; low and high end bracket the measured number.
By their numbers in this assay, from the lowest: compounds 1, 3, 2 and 4 (each within the scatter of the next, the first and the last beyond it).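

Removing one chlorine atom is enough to shift this read-out. In this assay, hydrogen in place of chloro on the aromatic carbon ortho to an isobutoxy group gives a 3.0-fold higher number from compound 1 to compound 4 (0.48 log units; beyond the scatter), whereas the change at the sulfonyl sulfur gave no change at the digits printed from compound 1 to compound 3 (within the scatter) and stayed within the scatter. This position is therefore the only one of the two changed singly where the free fraction moves, although compound 4, at 0.006, still has a very small free fraction, and no measurement here explains why the number rises.

The compounds shown leave open whether the rise belongs to the loss of chloro alone or would also appear with another small group on this carbon, such as fluoro, methyl or a nitrile. They also leave open whether the same swap would give a similar step with a methyl in place of the cyclopropyl on the sulfonyl sulfur, or with a shorter chain such as methoxy in place of the isobutoxy group.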